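The source may report more compounds than this note shows. Statements on the series, on what has been measured and on what is new or still open speak of the compounds shown alone.

Measured so far:
compound 1, `COCCOCCOc1nc(Nc2ccc(C#N)c(OCC=C(C)C)c2)nc(OC)n1`, 13000 nM
compound 2, `CCc1nc(Nc2ccc(C#N)c(OCC=C(C)C)c2)nc(OCCOC)n1`, 2100 nM

In an ADME assay on MT2 cells (Homo sapiens) for cytotoxicity, read by MTT assay (on this read-out lower numbers stand for higher toxicity in this test and higher numbers for lower toxicity in this test), compound 2 gives the lowest of the two numbers; compound 1 gives the higher number, a gap that lies beyond the scatter. Compound 3, `CCc1nc(Nc2ccc(C#N)c(OCC=C(C)C)c2)nc(OCCOCCOC)n1`, is not yet measured. It differs from compound 2 by methoxymethyl in place of hydrogen on a saturated chain carbon bound to an oxygen on a saturated carbon. Among the compounds with values here, no single-change step between measured compounds exists here, so the size of this step is unknown. A modest rise in the number is expected, within or just beyond the scatter, as a 1.5-fold higher number from compound 2 to compound 3 (0.18 log units; within the scatter). Compound 3 is estimated at 3200 nM, between 1200 nM and 8500 nM.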

Compound 3, half-maximal cytotoxic concentration: 9800 nM
The estimate for compound 3 lay 3.1-fold (0.49 log units) below the measured number; measured number outside the range, above it.
By their numbers in this assay, from the lowest: compound 2; then compounds 3 and 1 (each within the scatter of the next).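

In this assay, methoxymethyl in place of hydrogen on a saturated chain carbon bound to an oxygen on a saturated carbon gives a 4.7-fold higher number from compound 2 to compound 3 (0.67 log units; beyond the scatter) and so shifts the read-out beyond the scatter. Ethyl in place of methoxy on an aromatic carbon gives a 1.3-fold lower number from compound 1 to compound 3 (0.12 log units; within the scatter) and stays within the scatter, so this second change is not resolved by the assay. Nothing measured here accounts for either step. As far as these compounds go, whether a longer chain of the same kind would shift the number further remains open, as does whether an amine at the end of the chain would give a similar step.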